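Chloro for methyl on the anilide ring of compound 3

This account rests on a few compounds, and the source may have more. Where it says the series, first, only, none or still open, it means among the compounds named here.

Compound 3 `COc1cc2oc(-c3cccc(C(=O)Nc4ccc(C)cc4)c3)cc(=O)c2c(OC)c1OC` stands highest of the three measured numbers: in a functional assay on UACC-62 cells (Homo sapiens) for inhibition, read by sulforhodamine B assay, tested at 10 uM (a higher number here means more inhibition at the concentration tested (going by the name of the read-out), a lower number less inhibition), compound 3 gives 108%. Compound 1 `COc1cc2oc(-c3cccc(NC(=O)c4ccc(C)cc4)c3)cc(=O)c2c(OC)c1OC` gives 50.8% in this assay, and compound 2 `COc1cc2oc(-c3cccc(NC(=O)c4ccc(Br)cc4)c3)cc(=O)c2c(OC)c1OC` gives 39.1%. The orientation of the amide carries the large steps, a number 57.2 percentage points higher from compound 1 to compound 3 (beyond the scatter) and a number 68.9 percentage points higher from compound 2 to compound 3 (beyond the scatter), both beyond the scatter. Compound 4 `COc1cc2oc(-c3cccc(C(=O)Nc4ccc(Cl)cc4)c3)cc(=O)c2c(OC)c1OC` differs from compound 3 in one place: chloro in place of methyl on an aromatic carbon. Among the compounds with values here, the only measured step that concerns a halogen in place of methyl is a number 11.7 percentage points lower from compound 1 to compound 2 (beyond the scatter), a modest step beyond the scatter, but it sits in the other amide orientation and concerns bromo rather than chloro, so it bears on the present change only loosely. On that basis the step expected for compound 4 is small and, if anything, downward: a number 13 percentage points lower from compound 3 to compound 4 (beyond the scatter). Compound 4 is therefore expected to give about 95% in this assay, within a range of 70% to 115%.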

Compound 4, a percentage reported as inhibition, at one concentration (the size of the read-out at that concentration, not a potency): 107%
Compound 4: the middle estimate sits 12 percentage points below what was measured; low and high end bracket the measured number.
By their numbers in this assay, from the lowest: compound 2; then compound 1; then compounds 4 and 3 (each within the scatter of the next).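

In (this assay), going from 4-methylphenyl to 4-chlorophenyl leaves the read-out unchanged (a number 1 percentage points lower from compound 3 to compound 4 (within the scatter)), so within this amide orientation the two groups cannot be told apart at this position. The high number therefore does not depend on methyl: the chloro compound also stands well clear of both reversed amides (a number 67.9 percentage points higher from compound 2 to compound 4 (beyond the scatter)) (a number 56.2 percentage points higher from compound 1 to compound 4 (beyond the scatter)), although each of these two steps changes the ring substituent or its partner along with the amide, so neither isolates the orientation. No measurement at hand explains why chloro and methyl read alike here.

From the compounds shown here alone, whether other groups at this position, such as methoxy, an amine or a carboxylic acid, would hold the number stays open. Also open is whether chloro would match methyl in the reversed amide, where only methyl and bromo are shown.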